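Trimming the sulfonamide: a methyl in place of difluorophenyl

The compounds below may be only part of what the source reports. "The series", "measured", "known", "first", "only" and "open" are said of these compounds alone.

Three compounds have been measured in a functional assay on A549 cells (Homo sapiens) for antiproliferative activity, read by sulforhodamine B assay, with a stated time of 72 h; a higher number here means a weaker inhibitor, a lower number a stronger inhibitor:

Compound 1 `COc1ncc(-c2ccc3ncnc(Nc4ccc(OCCO)nc4)c3c2)cc1NS(C)(=O)=O`: 5080 nM
Compound 2 `COc1ncc(-c2ccc3ncnc(Nc4cnn(CCCO)c4)c3c2)cc1NS(=O)(=O)c1ccc(F)cc1F`: 4830 nM
Compound 3 `COc1ncc(-c2ccc3ncnc(Nc4ccc(OCCO)nc4)c3c2)cc1NS(=O)(=O)c1ccc(F)cc1F`: 4120 nM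

Compound 3 and compound 1 share a core and differ by methyl in place of 2,4-difluorophenyl on a sulfonyl sulfur; this step gave a 1.2-fold higher number from compound 3 to compound 1 (0.09 log units; within the scatter). Compound 2 carries a different core, which differs from the core of compound 3 by 1-(3-hydroxypropyl)-1H-pyrazol-4-yl in place of 6-(2-hydroxyethoxy)pyridin-3-yl on a nitrogen on an aromatic ring; that step gave a 1.2-fold lower number from compound 2 to compound 3 (0.07 log units; within the scatter). Compound 4 `COc1ncc(-c2ccc3ncnc(Nc4cnn(CCCO)c4)c3c2)cc1NS(C)(=O)=O` has not been measured yet; it differs from compound 2 by methyl in place of 2,4-difluorophenyl on a sulfonyl sulfur, at the same place with the same neighbours as in the measured pair, so this is the same kind of change. Compound 4 is expected to show a similarly small step, a 1.2-fold higher number from compound 2 to compound 4 (0.06 log units; within the scatter), because the earlier step measured a 1.2-fold higher number from compound 3 to compound 1 (0.09 log units; within the scatter). Compound 4 is therefore estimated at 5600 nM in this assay, plausibly between 2600 nM and 12000 nM.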

Compound 4, half-maximal inhibitory concentration: 3600 nM
Estimate against measurement, compound 4: 1.6-fold (0.19 log units) above, within the range that was stated.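

In this assay, methyl in place of 2,4-difluorophenyl on the sulfonyl sulfur gives a 1.3-fold lower number from compound 2 to compound 4 (0.13 log units; within the scatter), and exchanging the groups on the nitrogen on an aromatic ring gives a 1.4-fold lower number from compound 1 to compound 4 (0.15 log units; within the scatter). On both cores, the sulfonyl change stays small: the same change on two cores in this assay, a 1.2-fold higher number (0.09 log units; within the scatter) from compound 3 to compound 1 and a 1.3-fold lower number (0.13 log units; within the scatter) from compound 2 to compound 4, 1.7-fold (0.22 log units) apart, within the scatter of two such steps

The exchange on the nitrogen behaves alike, but steps this small show only that neither change moves the number beyond the scatter on these cores, not that either has a direction that carries over: the same change on two cores in this assay, a 1.2-fold lower number (0.07 log units; within the scatter) from compound 2 to compound 3 and a 1.4-fold higher number (0.15 log units; within the scatter) from compound 4 to compound 1, 1.7-fold (0.22 log units) apart, within the scatter of two such steps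

As far as these compounds go, what remains open is whether any group shifts the number beyond the scatter. A longer chain on the sulfonyl sulfur, or an amine or a carboxylic acid in place of the groups on the nitrogen, could answer that.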